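Amino Substitution on Two Nucleoside Cores

This account rests on a few compounds, and the source may have more. Where it says the series, first, only, none or still open, it means among the compounds named here.

Compound 2 `COc1ncnc2c1c(-c1ccccc1)cn2[C@@H]1O[C@H](CO)[C@@H](O)[C@H]1O` and compound 1 `COc1nc(N)nc2c1c(-c1ccccc1)cn2[C@@H]1O[C@H](CO)[C@@H](O)[C@H]1O` were both tested in a functional assay on K562 cells (Homo sapiens), read by MTT assay, with a stated time of 72 h; on this read-out higher numbers stand for weaker inhibition and lower numbers for stronger inhibition. In this assay compound 2 gives > 20000 nM, a limit of the assay rather than a number. Compound 1 likewise gives > 20000 nM, again only a limit. The change between them, (amino in place of hydrogen on an aromatic carbon), therefore yields a step that the two limits leave unreadable from compound 2 to compound 1. Compound 3 `O=c1[nH]cnc2c1c(-c1cc3ccccc3o1)cn2[C@@H]1O[C@H](CO)[C@@H](O)[C@H]1O` carries another core; the difference between the two cores is not broken down here. In this assay compound 3 gives > 20000 nM, also a limit. Compound 4 `Nc1nc2c(c(-c3cc4ccccc4o3)cn2[C@@H]2O[C@H](CO)[C@@H](O)[C@H]2O)c(=O)[nH]1` differs from compound 3 by amino in place of hydrogen on an aromatic carbon, the same kind of change, though here the place is meta to a group of 1 heavy atom rather than meta to a methoxy group (2 heavy atoms). Because all three measured compounds, compound 3 among them, sit at the limit of > 20000 nM in this assay, at which 3 of the 3 values shown sit, the step that the limit leaves unreadable from compound 3 to compound 4 is expected to remain unreadable. Compound 4 is therefore estimated at 30000 nM, expected to fall between 10000 nM and 100000 nM.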

Compound 4, half-maximal inhibitory concentration: > 20000 nM
Compound 4 was reported as a limit; the forecaster's own chance of this, stated with the estimate: 85%; the middle value lies beyond the limit too.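

No step can be read from compound 3 to compound 4, as both compounds stand only at a limit: the limit of > 20000 nM in this assay, at which 4 of the 4 values shown sit.

The compounds shown leave open whether amino in place of hydrogen on an aromatic carbon changes inhibition on either core.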